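Nitro removal on the sulfonyl aryl group: two anilide series

The source may report more compounds than this note shows. Statements on the series, on what has been measured and on what is new or still open speak of the compounds shown alone.

Measured so far in a functional assay for inhibition, read by spectrophotometry, with a stated time of 20 min, tested at 3 mg/mL; on this read-out higher numbers stand for a stronger effect at the one concentration tested and lower numbers for a weaker effect:
Compound 1, `CC(=O)c1ccc(NC(=O)C(CC(C)C)N(C(=O)c2ccccc2)S(=O)(=O)c2ccc([N+](=O)[O-])cc2)cc1`, gives 62.3%.
Compound 2, `CC(=O)c1ccc(NC(=O)C2CC(O)CN2S(=O)(=O)c2ccc([N+](=O)[O-])cc2)cc1`, gives 58.7%.
Compound 3, `CC(=O)c1ccc(NC(=O)C(CC(C)C)N(C(=O)c2ccccc2)S(=O)(=O)c2ccccc2)cc1`, gives 40.7%.

Compound 1 and compound 2 differ in more than one place; the difference between the two cores is not broken down here. Within the core of compound 1, the change hydrogen in place of nitro on an aromatic carbon gives the step of a number 21.6 percentage points lower from compound 1 to compound 3 (beyond the scatter) in this assay.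

Compound 4, `CC(=O)c1ccc(NC(=O)C2CC(O)CN2S(=O)(=O)c2ccccc2)cc1`, is not yet measured. It stands to compound 2 as compound 3 stands to compound 1: the change (hydrogen in place of nitro on an aromatic carbon), made at the same kind of place, the same change. Among the measured compounds shown here, since only one measured example of this change exists, the expectation for compound 4 rests on it alone. From compound 2 a step of a number 20.7 percentage points lower from compound 2 to compound 4 (beyond the scatter) is expected, because the same change in compound 1 gave a number 21.6 percentage points lower from compound 1 to compound 3 (beyond the scatter). Compound 4 is therefore estimated at 38%, between 22% and 54%.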

Compound 4, a percentage reported as inhibition, at one concentration (the size of the read-out at that concentration, not a potency): 49.8%
Compound 4: middle estimate off by 11.8 percentage points, on the low side; the measured number falls inside the stated range.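

Replacing 4-nitrophenyl with phenyl on the core of compound 2 gives a number 8.9 percentage points lower from compound 2 to compound 4 (within the scatter) in this assay. The steps on the two cores do not differ by more than the scatter allows: the same change on two cores in this assay, a number 21.6 percentage points lower (beyond the scatter) from compound 1 to compound 3 and a number 8.9 percentage points lower (within the scatter) from compound 2 to compound 4, 12.7 percentage points apart, within the scatter of two such steps. Among the compounds shown here, the data therefore show no core dependence in this change, but only the step on the core of compound 1 lies beyond the scatter, and two pairs read at one concentration neither fix a common size for the change nor prove that it is the same on both cores.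

The compounds shown leave open how an amine or a carboxylic acid on the same aromatic carbon would read in this assay. They also leave open how the change would read on any other core.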